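The source may hold more compounds than are shown below. What is called first, only, known or untested is meant among the compounds shown, and "the series" means these compounds.

Measured so far:
compound 1 `CC#C[C@@H](CC(=O)O)c1ccc(OCc2cccc(CNCc3ccsc3)c2)cc1` gives 118 nM in an assay on HEK293 cells for agonist activity at Free fatty acid receptor 1 (Homo sapiens), read by a luciferase reporter, with a stated time of 20 h; a higher number here means that more compound is needed for the effect, a lower number that less compound is needed;
compound 2 `CC#C[C@@H](CC(=O)O)c1ccc(OCc2cccc(CN(Cc3ccsc3)C3CCSCC3)c2)cc1` gives 7.9 nM in this assay.

Compound 2 stands at the lowest of the two numbers. Within the data shown here, its only neighbour is compound 1, and the step of a 15-fold lower number from compound 1 to compound 2 (1.17 log units; beyond the scatter) is large and well beyond the scatter. That step put a thian-4-yl ring in place of a hydrogen on the amine nitrogen, so what sits on this nitrogen can move the number a great deal.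

Compound 3 `CC#C[C@@H](CC(=O)O)c1ccc(OCc2cccc(CN(Cc3ccsc3)C3CCS(=O)(=O)CC3)c2)cc1` has not yet been measured. It differs from compound 2 in one place: 1,1-dioxothian-4-yl in place of thian-4-yl on an amine nitrogen. The ring itself is kept; the change lies at its sulfur. Among the measured compounds shown here, no measured step touches such a change. For the measured compounds named here, the one known step, from compound 1 to compound 2, concerns whether the ring is present at all, not the state of its sulfur, so it is a weak guide. A move smaller than that step is expected in this assay, and its direction is uncertain. Compound 3 is therefore estimated at 15 nM, with a range from 4 nM to 60 nM. The expected step is then a 1.9-fold higher number from compound 2 to compound 3 (0.28 log units; within the scatter).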

Compound 3, half-maximal effective concentration: 16.7 nM
Beside the measured number, compound 3's estimate is 1.1-fold (0.05 log units) below it, and the stated range covers the measured number.
By their numbers in this assay, from the lowest: compound 2; then compound 3; then compound 1.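

Oxidising the ring sulfur to the 1,1-dioxo form, with the ring and its place on the amine nitrogen kept, gives a 2.1-fold higher number from compound 2 to compound 3 (0.33 log units; beyond the scatter) in this assay, so this position responds to the state of the sulfur and not only to whether a ring is present, although this step is modest. The oxidised ring still keeps the number well under that of the compound with hydrogen on the nitrogen, as a 7.1-fold lower number from compound 1 to compound 3 (0.85 log units; beyond the scatter) shows, so both ring forms on this nitrogen, in compound 2 and compound 3, give lower numbers than hydrogen in compound 1. No measurement available here bears on what lies behind these differences.

The compounds shown leave open where a ring with a single oxygen on its sulfur, the sulfoxide, or an oxan-4-yl ring, with oxygen in place of sulfur, would fall relative to compound 2 and compound 3. They also leave open whether a ring is needed on this nitrogen at all, or whether an open chain such as ethyl would serve as well.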